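The source may hold more compounds than are shown below. What is called first, only, known or untested is meant among the compounds shown, and "the series" means these compounds.

Working notes on a small set of fused-core analogues. Compound 1 `ClCc1ccccc1Cn1cnc2c(Cl)nc(Cl)nc21`, compound 2 `ClCc1ccccc1Cn1cnc2c(Cl)ncnc21` and compound 3 `ClCc1cccc(Cn2cnc3c(Cl)ncnc32)c1` have been run in a functional assay on MDA-MB-231 cells (Homo sapiens) for cytotoxicity, read by sulforhodamine B assay, with a stated time of 48 h; on this read-out lower numbers stand for higher toxicity in this test and higher numbers for lower toxicity in this test. In this assay compound 1 gives 3980 nM, compound 2 gives 45700 nM and compound 3 gives 8120 nM. Compound 1 and compound 2 differ by one change, (chloro in place of hydrogen on an aromatic carbon), and the measured step is an 11-fold lower number from compound 2 to compound 1 (1.06 log units; beyond the scatter). Compound 3 and compound 2 are built from the same atoms joined differently; the difference between the two cores is not broken down here. Compound 3 stands second highest of the three numbers, nearest to compound 1 and furthest from compound 2.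

Compound 4 `ClCc1cccc(Cn2cnc3c(Cl)nc(Cl)nc32)c1` is not yet measured in this assay. It differs from compound 3 by chloro in place of hydrogen on an aromatic carbon, the same change already seen in the pair of compound 2 and compound 1; the change occurs twice in all among the compounds here. Among the measured compounds shown here, the expected step in this assay is a 10-fold lower number from compound 3 to compound 4 (1.01 log units; beyond the scatter), resting on the single measured example, an 11-fold lower number from compound 2 to compound 1 (1.06 log units; beyond the scatter). Compound 4 is accordingly estimated at 800 nM in this assay, with a likely range from 300 nM to 2500 nM.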

Compound 4, concentration lethal to 50% of the cells: 7240 nM
Compound 4: middle estimate off by 9.1-fold (0.96 log units), on the low side; the measured number lies above the stated range.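

In this assay, chloro in place of hydrogen on an aromatic carbon gives a 1.1-fold lower number from compound 3 to compound 4 (0.05 log units; within the scatter). The size of the step therefore does not carry from one core to the other in this series: the same change on two cores in this assay, an 11-fold lower number (1.06 log units; beyond the scatter) from compound 2 to compound 1 and a 1.1-fold lower number (0.05 log units; within the scatter) from compound 3 to compound 4, 10-fold (1.01 log units) apart, beyond the scatter of two such steps

The large step seen on the core of compound 1 is thus no guide to the step on the core of compound 4, but two pairs do not show why the steps differ, nor what the change would do on any further core. The compounds shown leave open whether another group on the same aromatic carbon, such as an amine or a methoxy group, would also give steps that differ between the two cores. They also leave open whether the gap between the two steps would persist if the chloromethyl group on the benzene ring gave way to a hydroxymethyl group or a longer chain.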